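Lengthening the Amide Chain by One Carbon

This account rests on a few compounds, and the source may have more. Where it says the series, first, only, none or still open, it means among the compounds named here.

Within the data shown here, compound 1 `CNC(=O)CCCc1cccc2c1OCCO2` is one of two compounds measured in an assay (Ovis aries) for binding affinity to melatonin receptor type 1A (Homo sapiens); a lower number here means a stronger inhibitor, a higher number a weaker inhibitor. In this assay compound 1 gives 15.9 nM. The other compound, compound 2 `COc1ccc2cccc(CCC(N)=O)c2c1`, gives 1000 nM in this assay, a much higher number than that of compound 1, so compound 1 stands as the lower of the two numbers, and the gap between them lies beyond the usual scatter.

Compound 3 `CNC(=O)CCCCc1cccc2c1OCCO2` has not yet been measured. It differs from compound 1 in one place: (methylcarbamoyl)methyl in place of methylcarbamoyl on a saturated chain carbon, three bonds along the chain from an aromatic carbon. In plain words, the chain that links the amide to the shared core of compound 1 is one carbon longer in compound 3; everything else is the same.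

Among the measured compounds shown here, no measured pair in this set shows what such a lengthening does, so the expectation rests only on the two numbers above and on the change itself. The step from compound 1 to compound 3 is expected to be a 3.1-fold higher number from compound 1 to compound 3 (0.50 log units; beyond the scatter), a moderate weakening, as the core and amide are unchanged and only the spacer grows. Compound 3 is therefore estimated to give 50 nM in this assay, within a range from 10 nM to 300 nM.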

Compound 3, half-maximal inhibitory concentration: 50.1 nM
The estimate for compound 3 lay 1.0-fold (0.00 log units) below the measured number, and the stated range covers the measured number.
By their numbers in this assay, from the lowest: compound 1; then compound 3; then compound 2.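

The set now holds its first pair of compounds that differ in only one place, so the effect of this change can be read directly rather than inferred from two unrelated structures. In this assay, placing (methylcarbamoyl)methyl where methylcarbamoyl stood, on a saturated chain carbon three bonds along the chain from an aromatic carbon, gives a 3.2-fold higher number from compound 1 to compound 3 (0.50 log units; beyond the scatter), a modest weakening that is nevertheless beyond the usual scatter, so the length of this chain does register in the number, but the added carbon does not abolish binding. No measurement available here explains why the longer chain gives the higher number.

On these data alone, a single step between two chain lengths cannot define a trend, so it remains open whether a shorter chain would lower the number or a longer chain would raise it further. As far as these compounds go, it is equally open how the number would respond if the amide at the end of either chain gave way to another group, such as an amine or a carboxylic acid.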